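A phenoxy-to-phenylcarbamoyl swap on the shared core

This account rests on a few compounds, and the source may have more. Where it says the series, first, only, none or still open, it means among the compounds named here.

Compound 1 `NCc1cc(Oc2cccc(Oc3ccccc3)c2)nc(C(F)(F)F)c1` carries a phenoxy group on its core. In an ADME assay on the whole organism (plasma, Mus musculus) for pharmacokinetics, read by LC-MS, at a dose of 30 mg/kg by the oral route (a higher number here means more compound in the circulation at the dose given, a lower number less compound in the circulation), compound 1 gives "not determined" (no result reported), so it stands nowhere on the numbers at hand. Its amide-bearing relatives are measured: compound 2 `CONC(=O)c1cccc(Oc2cc(CN)cc(C(F)(F)F)n2)c1` gives 630 nM and compound 3 `NCc1cc(Oc2cccc(C(=O)NC[C@@H](O)CO)c2)nc(C(F)(F)F)c1` gives 2770 nM, with a 4.4-fold higher number from compound 2 to compound 3 (0.64 log units; beyond the scatter). Compound 4 `NCc1cc(Oc2cccc(C(=O)Nc3ccccc3)c2)nc(C(F)(F)F)c1` differs from compound 1 by phenylcarbamoyl in place of phenoxy on an aromatic carbon. Among the measured compounds shown here, no measured step changes this position, and the one known step concerns the substituent on an amide-type nitrogen, so it bears only loosely on compound 4. Since compound 2 and compound 3 both carry an amide at the same place, compound 4 is expected to fall near them, estimated at 900 nM with a range of 200 nM to 3500 nM.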

Compound 4, maximal plasma concentration: 860 nM
Estimate against measurement, compound 4: 1.0-fold (0.02 log units) above; low and high end bracket the measured number.
By their numbers in this assay, from the lowest: compounds 2 and 4 (each within the scatter of the next); then compound 3.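

In this assay, phenyl on the amide-type nitrogen gives two new readings: against 2,3-dihydroxypropyl (a 3.2-fold lower number from compound 3 to compound 4 (0.51 log units; beyond the scatter)) and against methoxy (a 1.4-fold higher number from compound 2 to compound 4 (0.14 log units; within the scatter)). The second step lies within the scatter, so phenyl and methoxy are not told apart here, and among these three compounds only the 2,3-dihydroxypropyl of compound 3 stands apart. No measurement shown here accounts for this difference. The phenoxy-to-phenylcarbamoyl swap itself cannot be read, as compound 1 has no number. As far as these compounds go, whether a longer chain ending in a carboxylic acid or an amine would behave like the 2,3-dihydroxypropyl remains open.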